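This account rests on a few compounds, and the source may have more. Where it says the series, first, only, none or still open, it means among the compounds named here.

Measured compounds on hand:

compound 1, `COc1ccc(OC)c(N2C(=O)CSC2c2cccc(C(=O)NCCCCc3ccccc3)c2)c1` — 1%
compound 2, `COc1ccc(F)cc1N1C(=O)CSC1c1cccc(C(=O)NCCCCc2ccccc2)c1` — 32%

In a functional assay on U2OS cells (Homo sapiens) for inhibition, read by CCK-8 assay, with a stated time of 72 h, tested at 1 uM (a higher number here means more inhibition at the concentration tested (going by the name of the read-out), a lower number less inhibition), compound 1 gives 1%, the lowest of the two numbers; the nearest value is that of compound 2, which gives 32% in this assay. For the measured compounds named here, the one measured step, a number 31 percentage points higher from compound 1 to compound 2 (beyond the scatter), came from a fluoro in place of a methoxy on an aromatic carbon of the group on the amide-type nitrogen in the ring.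

Compound 3, `COc1cc(F)ccc1N1C(=O)CSC1c1cccc(C(=O)NCCCCc2ccccc2)c1`, has not yet been measured in this assay. It differs from compound 1 as follows: 4-fluoro-2-methoxyphenyl in place of 2,5-dimethoxyphenyl on an amide-type nitrogen in a ring. This is not the same change as the one measured: here one methoxy leaves and a fluorine enters on a different aromatic carbon of the same group. The step from compound 1 to compound 2 is the only one bearing on it, and it was large, so a rise in this assay is expected for compound 3, though probably of smaller size, as the step to compound 2 does not match the change exactly. The expected step is a number 19 percentage points higher from compound 1 to compound 3 (beyond the scatter). Compound 3 is estimated at 20%, within a range of 0% to 45%.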

Compound 3, a percentage reported as inhibition, at one concentration (the size of the read-out at that concentration, not a potency): 34%
Compound 3: middle estimate off by 14 percentage points, on the low side; measured number inside the range.
By their numbers in this assay, from the lowest: compound 1; then compounds 2 and 3 (each within the scatter of the next).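

In this assay, 4-fluoro-2-methoxyphenyl in place of 2,5-dimethoxyphenyl on the amide-type nitrogen in the ring gives a number 33 percentage points higher from compound 1 to compound 3 (beyond the scatter), so a second fluorine-bearing group now stands clear of compound 1 at this place. Moving the fluorine, with 4-fluoro-2-methoxyphenyl in place of 5-fluoro-2-methoxyphenyl, gives a number 2 percentage points higher from compound 2 to compound 3 (within the scatter), so this assay does not separate these two groups, and among the three compounds both fluorine-bearing groups lie beyond the scatter from the 2,5-dimethoxyphenyl group, with no compound going against this. No measured evidence on the compounds accounts for either step.

Still open, as far as these compounds go, is whether the entering fluorine or the departing second methoxy carries the rise, a question that plain 2-methoxyphenyl on the same nitrogen would address. Also open, from the compounds shown here alone, is whether a chloro, a nitrile or an amine on the carbon bearing the fluorine would hold the number, and how these single-concentration numbers would translate into potency.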